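The source may hold more compounds than are shown below. What is called first, only, known or untested is meant among the compounds shown, and "the series" means these compounds.

Measured in a functional assay for inhibition, with Homo sapiens as the target; a lower number here means tighter binding, a higher number weaker binding:
- Compound 1 `O=C(O)CC/C=C\CC1COC(c2ccccc2Cl)OC1c1cccnc1`: 759 nM
- Compound 2 `O=C(O)CC/C=C\CC1COC(c2ccc([N+](=O)[O-])cc2)OC1c1cccnc1`: 933 nM
- Compound 3 `Cc1ccc(C#N)c(OC(C)(C)C2OCC(C/C=C\CCC(=O)O)C(c3cccnc3)O2)c1`: 15.9 nM

Compound 3 holds the lowest number of the three, beyond the scatter from both others. Compound 4 `Cc1ccc(OC(C)(C)C2OCC(C/C=C\CCC(=O)O)C(c3cccnc3)O2)cc1` differs from it in one place: 4-methylphenyl in place of 2-cyano-5-methylphenyl on an oxygen on a saturated carbon. Among the compounds with values here, only one measured step exists, a 1.2-fold higher number from compound 1 to compound 2 (0.09 log units; within the scatter), and it concerns a saturated ring carbon, so it bears only weakly on this change. Within the data shown here, no measured step removes the nitrile. With compound 3 at 15.9 nM, the bottom of the measured range, a moderate rise is expected rather than a further fall. The expected change is a 3.1-fold higher number from compound 3 to compound 4 (0.50 log units; beyond the scatter). Compound 4 is estimated at 50 nM, with an expected range from 12 nM to 200 nM.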

Compound 4, dissociation constant: 631 nM
Beside the measured number, compound 4's estimate is 13-fold (1.10 log units) below it, outside the stated range (above it).
By their numbers in this assay, from the lowest: compound 3; then compounds 4, 1 and 2 (each within the scatter of the next).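

In this assay, within the data shown here, the change on the oxygen on a saturated carbon gives a 40-fold higher number from compound 3 to compound 4 (1.60 log units; beyond the scatter) and is large, whereas the only earlier step, on a saturated ring carbon, stayed within the scatter. The number at this position therefore depends strongly on which aryl group is attached, and 2-cyano-5-methylphenyl gives the lowest value of the set. Nothing available explains the size of this step.

The step changes the nitrile and the methyl placement together, so their shares remain unseparated. From the compounds shown here alone, whether 2-cyanophenyl or 4-cyanophenyl would keep the low number remains open.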